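The source may hold more compounds than are shown below. What is called first, only, known or untested is meant among the compounds shown, and "the series" means these compounds.

Measured so far in an ADME assay on the whole organism with Oryza sativa as the target, tested at 10 uM; on this read-out lower numbers stand for a stronger effect and higher numbers for a weaker effect at the one concentration tested:
compound 1 `Cc1cccc(NC(=O)N[C@H](C)c2ccccc2)c1` gives 47%;
compound 2 `Cc1cccc(NC(=O)N[C@@H](C)c2ccccc2)c1` gives 100%;
compound 3 `CC(C)c1ccccc1NC(=O)N[C@H](C)c1ccccc1` gives 17%.

Compound 2 stands highest of the three, above compound 1 and further above compound 3. Among the measured compounds shown here, the one step measured in one place is a number 53 percentage points higher from compound 1 to compound 2 (beyond the scatter), which rests on the fact that compounds 1 and 2 differ only in the configuration as drawn alone. Compound 4 `C[C@H](NC(=O)Nc1cccc(Cl)c1)c1ccccc1` keeps the configuration of compound 2 and changes only the substituent: chloro in place of methyl on an aromatic carbon. For the measured compounds named here, no measured step bears on a substituent change on this ring; compounds 1 and 3 differ in more than one place, so only their two values can be set side by side. The step is therefore expected to be a number 15 percentage points lower from compound 2 to compound 4 (beyond the scatter), with the weak-effect end of the scale as a ceiling. Compound 4 is estimated at 85%, between 55% and 100%.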

Compound 4, a percentage reported as activity, at one concentration (the size of the read-out at that concentration, not a potency): 103%
Compound 4: middle estimate off by 18 percentage points, on the low side; the measured number lies above the stated range.
By their numbers in this assay, from the lowest: compound 3; then compound 1; then compounds 2 and 4 (each within the scatter of the next).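

In this assay, chloro in place of methyl on an aromatic carbon, meta to a large group, gives a number 3 percentage points higher from compound 2 to compound 4 (within the scatter). With the configuration of compound 2, the two groups therefore cannot be told apart at this position, and both compounds lie at the weak-effect end of the scale. Nothing available bears on why they read alike. On these data alone, whether chloro would also match methyl in the configuration of compound 1, which gives 47%, remains open. So does the reading with an amine or a methoxy group at this position.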